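From Compound 2 to Compound 3: One Ring Swapped

The source may report more compounds than this note shows. Statements on the series, on what has been measured and on what is new or still open speak of the compounds shown alone.

Of the compounds shown here, two have been measured in an assay on T-REx-293 cells for inhibition of potassium channel subfamily T member 1 (Homo sapiens), read by patch clamp; on this read-out higher numbers stand for weaker inhibition and lower numbers for stronger inhibition. Compound 1 `Cc1cccc(-c2noc([C@H](C)NC(=O)c3cc(C4CC4)nn3C)n2)c1` gives 167 nM in this assay. Compound 2 `Cc1ccnc(-c2noc([C@H](C)NC(=O)c3cc(C(F)(F)F)nn3C)n2)c1` gives 4470 nM in this assay, the higher of the two numbers, and the gap between compound 2 and compound 1 lies well beyond the usual scatter of repeated measurements, so compound 2 is the weaker inhibitor of the pair.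

Compound 3 `Cc1cc(-c2noc([C@H](C)NC(=O)c3cc(C(F)(F)F)nn3C)n2)ncn1` has not yet been measured. It differs from compound 2 in a single place: 6-methylpyrimidin-4-yl in place of 4-methylpyridin-2-yl on an aromatic carbon. Among the measured compounds shown here, no measured pair in this small set shows such a swap, so there is no direct precedent to lean on. The expectation is a modest shift toward weaker inhibition, though one that may not clearly exceed the scatter; the expected step is a 1.5-fold higher number from compound 2 to compound 3 (0.16 log units; within the scatter). Compound 3 is therefore estimated to give 6500 nM in this assay, with a likely range from 2200 nM to 20000 nM.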

Compound 3, half-maximal inhibitory concentration: 1410 nM
Compound 3: middle estimate off by 4.6-fold (0.66 log units), on the high side, and the stated range ends above it.
By their numbers in this assay, from the lowest: compound 1; then compound 3; then compound 2.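

At this carbon of the five-membered aromatic ring, in this assay the change to 6-methylpyrimidin-4-yl from 4-methylpyridin-2-yl gives a 3.2-fold lower number from compound 2 to compound 3 (0.50 log units; beyond the scatter) and this step lies beyond the usual scatter of repeated measurements. Among the compounds shown here, it is the first comparison here of two compounds that differ in one place, and it shows that the ring at this position can shift inhibition: with the heavy-atom count unchanged, the ring holding the extra nitrogen goes with the stronger inhibitor of the pair. Nothing available explains the step, so it stands as an observation.

From the compounds shown here alone, whether the same swap would give a similar step with cyclopropyl in place of trifluoromethyl stays open. Also open, going by these compounds, is how this ring would behave with an amine or a methoxy group in place of its methyl.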